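This account rests on a few compounds, and the source may have more. Where it says the series, first, only, none or still open, it means among the compounds named here.

Of the compounds shown here, two of a shared core have been measured in a functional assay on HeLa cells (Homo sapiens) for inhibition, with a stated time of 72 h; a higher number here means that more compound is needed for the effect, a lower number that less compound is needed. Compound 1 `COc1cc(CNCCCN(C)C)ccc1OCc1ccc(Cl)nc1` gives 5000 nM in this assay, which is the highest of the two numbers seen so far. Compound 2 `COc1cc(CNCCNc2ccnc3cc(Cl)ccc23)ccc1OCc1ccc(Cl)nc1` gives 2700 nM in this assay, and that number sits within the usual scatter of the number for compound 1, so the two compounds cannot be told apart on these data.

Compound 3 `COc1cc(CNCc2cccs2)ccc1OCc1ccc(Cl)nc1` has not yet been measured in this assay. It differs from compound 1 in one place: thiophen-2-yl in place of 2-(dimethylamino)ethyl on a saturated chain carbon bound to an amine nitrogen. Among the compounds with values here, no measured pair shows this or any single change, so there is nothing on which to anchor the size of the step. Within the data shown here, compound 3 keeps the core of compound 1, and with only two numbers in hand, both of them close to each other, the expected step from compound 1 to compound 3 is a 1.3-fold higher number from compound 1 to compound 3 (0.11 log units; within the scatter), a modest move toward a higher number that may well stay within the scatter. Compound 3 is therefore estimated at 6500 nM in this assay, with a range from 1500 nM to 28000 nM.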

Compound 3, half-maximal effective concentration: 96000 nM
Compound 3: the middle estimate sits 15-fold (1.17 log units) below what was measured; the measured number lies above the stated range.
By their numbers in this assay, from the lowest: compounds 2 and 1 (each within the scatter of the next); then compound 3.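

In this assay, within the data shown here, the group on a saturated chain carbon bound to an amine nitrogen proves to matter a great deal: thiophen-2-yl in place of 2-(dimethylamino)ethyl gives a 19-fold higher number from compound 1 to compound 3 (1.28 log units; beyond the scatter), the first single change that can be read here. The two groups match in heavy atoms, hydrogen-bond donors, hydrogen-bond acceptors and net charge, so these counts do not track the step, while the entering group brings a five-membered aromatic ring with sulfur and the leaving group is an open chain with a nitrogen. No measurement at hand accounts for the size of this step.

The shown compounds leave open whether the step goes with the loss of the dimethylamino nitrogen, the arrival of the thiophene ring, or both, as the two happen together in this single change. A plain propyl chain in place of 3-(dimethylamino)propyl would speak to the first of these, and a (furan-2-yl)methyl or benzyl group in place of (thiophen-2-yl)methyl would show how far the number depends on the particular ring.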